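The compounds below may be only part of what the source reports. "The series", "measured", "known", "first", "only" and "open" are said of these compounds alone.

Compound 1 `COc1ccc([C@@H]2Oc3cc(OC)c(O)c(OC)c3C(=O)[C@@H]2O)cc1OC` and compound 2 `COc1ccc([C@@H]2Oc3cc(OC)c(OC)c(OC)c3C(=O)[C@@H]2O)cc1OC` differ by methyl in place of hydrogen on an oxygen on an aromatic ring. In a functional assay on PC-12 cells (Rattus norvegicus) for cytotoxicity, read by MTT assay, with stated times of 2 h and 4 h, tested at 16 ug/mL (a higher number here means a stronger effect of the compound at the concentration tested, a lower number a weaker effect), compound 1 gives 19.8%, while compound 2 gives 1.9%, the lowest of the two numbers, the drop a number 17.9 percentage points lower from compound 1 to compound 2 (beyond the scatter) being beyond the scatter. Compound 3 `COc1cc([C@@H]2Oc3cc(OC)c(OC)c(OC)c3C(=O)[C@@H]2O)cc(OC)c1OC` is not yet measured in this assay and carries methoxy in place of hydrogen on an aromatic carbon. For the measured compounds named here, no measured step concerns a change on an aromatic carbon, so a number 17.9 percentage points lower from compound 1 to compound 2 (beyond the scatter) is no direct guide, and the low number of compound 2 leaves little room for a further fall. The step of a number 3.1 percentage points higher from compound 2 to compound 3 (within the scatter) is expected to stay within the scatter. Compound 3 is therefore estimated at 5%, range 0% to 20%.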

Compound 3, a percentage reported as activity, at one concentration (the size of the read-out at that concentration, not a potency): 9.2%
For compound 3 the middle estimate is 4.2 percentage points below the measured one; measured number inside the range.
By their numbers in this assay, from the lowest: compounds 2 and 3 (each within the scatter of the next); then compound 1.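

For the compounds shown here, this position on the aromatic ring, ortho to a methoxy group and meta to a large group, is the first aromatic carbon to be changed. In this assay, methoxy in place of hydrogen there gives a number 7.3 percentage points higher from compound 2 to compound 3 (within the scatter), so compound 2 and compound 3 cannot be told apart. No data on a cause of this result are at hand. Going by these compounds, whether an amine or a carboxylic acid at this carbon would read differently stays open. So does whether methoxy here behaves the same on the core of compound 1, with its free hydroxy group.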